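Working notes: ester replacement on compound 1

A few compounds are considered here, and "the series" means these few. Any claim that something is new, unique, unknown or untested is made for them only; others in the source may bear on it.

Measured in an assay on membranes from HEK293 cells for displacement of a labelled ligand from adenosine receptor A2b (Homo sapiens), read by scintillation counting, with a stated time of 30 min, tested at 1 uM; on this read-out higher numbers stand for more inhibition at the one concentration tested (going by the name of the read-out) and lower numbers for less inhibition:
compound 1 `CC1=C(C(=O)OC(C)(C)C)C(c2cccs2)NC(=O)N1` gives 38%
compound 2 `CC1=C(C(=O)OC(C)(C)C)C(c2ccsc2)NC(=O)N1` gives 47%
compound 3 `CC1=C(C(=O)OC(C)(C)C)C(c2cccs2)NC(=O)N1C` gives 24%

Compound 1 stands second highest of the three numbers. Its nearest neighbour is compound 2, with a number 9 percentage points higher from compound 1 to compound 2 (within the scatter); the furthest is compound 3, with a number 14 percentage points lower from compound 1 to compound 3 (beyond the scatter).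

Compound 4 `CCCC(=O)C1=C(C)NC(=O)NC1c1cccs1` differs from compound 1 at the ester only: propyl in place of tert-butoxy on a carbonyl carbon. Neither measured step touches this carbonyl carbon; one concerns the thiophene attachment, the other the ring nitrogen. Going by the values given here, no measured step therefore bears directly on the change, and the expectation is no step beyond the scatter in this assay, a number 2 percentage points lower from compound 1 to compound 4 (within the scatter). For compound 4 the estimated value in this assay is 36%, expected within 16% to 56%.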

Compound 4, a percentage reported as inhibition, at one concentration (the size of the read-out at that concentration, not a potency): 9%
The estimate for compound 4 lay 27 percentage points above the measured number, and the stated range ends above it.
By their numbers in this assay, from the lowest: compound 4; then compound 3; then compounds 1 and 2 (each within the scatter of the next).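

Propyl in place of tert-butoxy on a carbonyl carbon gives a number 29 percentage points lower from compound 1 to compound 4 (beyond the scatter), so this position is sensitive to the group carried there. The earlier steps shown here, at the thiophene attachment and the ring nitrogen, gave no reading of this. Nothing shown gives a reason for the step.

From the compounds shown here alone, it remains open whether an ethoxy group, an amine or a longer chain on this carbonyl carbon would stay nearer compound 1 or nearer compound 4. Going by these compounds, whether the same replacement has a similar effect alongside the thiophen-3-yl group of compound 2 also remains open.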